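The source may hold more compounds than are shown below. What is called first, only, known or untested is meant among the compounds shown, and "the series" means these compounds.

Compound 1 `CN1CCc2c(sc(NC(=O)c3ccc(Cl)cc3)c2C(N)=O)C1` in an ADME assay on RAW264.7 cells (Mus musculus) for cytotoxicity, read by MTT assay, with a stated time of 48 h, tested at 50 uM (on this read-out lower numbers stand for less inhibition and higher numbers for more inhibition at the one concentration tested (going by the name of the read-out)), gives 38.5%. Compound 2 `CC(C)(C)OC(=O)N1CCc2c(sc(NC(=O)c3ccc(Cl)cc3)c2C(N)=O)C1` in this assay gives 37.3%. Compound 3 `NC(=O)c1c(NC(=O)c2ccc(Cl)cc2)sc2c1CCN(Cc1ccccc1)C2` in this assay gives 11.1%.

Compound 3 stands lowest of the three, with compound 2 nearest and compound 1 furthest, both separated from it beyond the scatter (a number 26.2 percentage points lower from compound 2 to compound 3 (beyond the scatter); a number 27.4 percentage points lower from compound 1 to compound 3 (beyond the scatter)). The unmeasured compound 4 `NC(=O)c1c(NC(=O)c2ccc(OCc3ccccc3)cc2)sc2c1CCN(Cc1ccccc1)C2` differs from compound 3 in one place: benzyloxy in place of chloro on an aromatic carbon. Within the data shown here, none of the measured steps touches this aromatic ring; all three concern the amine nitrogen in the ring, so no measured step bears directly on this change. With nothing to point either way, the expectation is a step of about a number 0.9 percentage points higher from compound 3 to compound 4 (within the scatter), within the scatter. Compound 4 is therefore estimated at 12%, in the range 0% to 30%.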

Compound 4, a percentage reported as inhibition, at one concentration (the size of the read-out at that concentration, not a potency): 24%
Compound 4: middle estimate off by 12 percentage points, on the low side; the measured number falls inside the stated range.
By their numbers in this assay, from the lowest: compound 3; then compound 4; then compounds 2 and 1 (each within the scatter of the next).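

The earlier compounds shown here changed only the amine nitrogen in the ring; this pair shows that the aromatic carbon carrying chloro also matters in this assay, with a number 12.9 percentage points higher from compound 3 to compound 4 (beyond the scatter) when benzyloxy replaces chloro. This is a single pair, with benzyl held on the amine nitrogen. No measurement here explains the rise.

As far as these compounds go, whether a methoxy group or an amine at this place would shift the number likewise remains open. So does whether the swap behaves the same with methyl or tert-butoxycarbonyl on that nitrogen.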